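The source may report more compounds than this note shows. Statements on the series, on what has been measured and on what is new or still open speak of the compounds shown alone.

Measured compounds in an assay on isolated protein for inhibition of Deoxyuridine 5'-triphosphate nucleotidohydrolase, mitochondrial (Homo sapiens); on this read-out higher numbers stand for weaker inhibition and lower numbers for stronger inhibition:
Compound 1 `O=c1ccn(CCCO[Si](c2ccccc2)(c2ccccc2)c2ccccc2)c(=O)[nH]1` gives 25000 nM.
Compound 2 `O=c1ccn(CCCO)c(=O)[nH]1` gives only the assay limit > 1000000 nM.
Compound 3 `O=c1ccn(CCCCCO)c(=O)[nH]1` gives only the assay limit > 1000000 nM.

Compound 3 thus stands at the limit of this assay rather than at a number; two of the three results shown sit at that point (the limit of > 1000000 nM in this assay, at which 2 of the 3 values shown sit). Compound 4 `O=c1ccn(CCCCCCO)c(=O)[nH]1` differs from compound 3 by hydroxymethyl in place of hydroxy on a saturated chain carbon, five bonds along the chain from an aromatic nitrogen. Among the measured compounds shown here, the only measured step of the same kind, a step that the two limits leave unreadable from compound 2 to compound 3, runs between two limits and so has no readable size. With no readable step to build on, compound 4 is expected to reach no measurable number either, and the step that the limit leaves unreadable from compound 3 to compound 4 is estimated as none beyond the scatter. Compound 4 is accordingly estimated at 1500000 nM, with a range from 300000 nM to 5000000 nM.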

Compound 4, inhibition constant: 636000 nM
Compound 4: the middle estimate sits 2.4-fold (0.37 log units) above what was measured; low and high end bracket the measured number.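

In this assay, among the compounds shown here, compound 4 is the first compound ending in a free hydroxy group to give a number rather than a limit, so this one-carbon extension brings the chain into the measurable range. The result amounts to an at least 1.5-fold lower number from compound 3 to compound 4 (0.19 log units; that floor lies within the scatter) and an at least 1.5-fold lower number from compound 2 to compound 4 (0.19 log units; that floor lies within the scatter), so neither floor alone proves a real gain. The remaining step, between the two shorter chains, cannot be read: the limit of > 1000000 nM in this assay, at which 2 of the 4 values shown sit.

Going by these compounds, whether a longer chain would lower the number further remains open. So does whether an amine or a carboxylic acid at the chain end would act like the hydroxy group.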